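Turning One Double Bond from E to Z

The compounds below may be only part of what the source reports. "The series", "measured", "known", "first", "only" and "open" are said of these compounds alone.

In an ADME assay on HFF cells (Homo sapiens) for cytotoxicity, read by neutral red uptake (on this read-out lower numbers stand for higher toxicity in this test and higher numbers for lower toxicity in this test), compound 1 `Nc1nc2c(ncn2/C=C2\C[C@@H]2[C@H](O)CO)c(=O)[nH]1` gives > 300000 nM, which is a limit of the assay and not a number. Compound 2 `Nc1nc2c(ncn2/C=C2\C[C@@H]2[C@@H](O)CO)c(=O)[nH]1` gives > 300000 nM, also a limit. Within the data shown here, compound 3 `Nc1nc2c(ncn2/C=C2\C[C@H]2[C@@H](O)CO)c(=O)[nH]1` gives 298000 nM, the only actual number of the three. Compound 4 `Nc1nc2c(ncn2/C=C2/C[C@H]2[C@@H](O)CO)c(=O)[nH]1` differs from compound 3 as follows: the two compounds have the same atoms and bonds and differ only in configuration as drawn: 1 of 3 stereo elements differ; a double bond is drawn E in compound 3 and Z in compound 4. The closest measured change, a number no higher from compound 2 to compound 3 (the limit leaves the size open), also alters configuration alone, but at a saturated ring carbon. The same holds for a step that the two limits leave unreadable from compound 1 to compound 2, at a saturated chain carbon, and a number no higher from compound 1 to compound 3 (the limit leaves the size open), at both. None of these has a readable size or involves the double bond, so no change beyond the usual scatter is expected: the expected step is a 1.0-fold lower number from compound 3 to compound 4 (0.01 log units; within the scatter). Compound 4 is estimated at 290000 nM, with an expected range from 150000 nM to 450000 nM.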

Compound 4, half-maximal cytotoxic concentration: 299000 nM
The estimate for compound 4 lay 1.0-fold (0.01 log units) below the measured number; the range from low to high includes it.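

In this assay, among these compounds, the double bond gives the first step in this set with a readable size: going from E to Z gives a 1.0-fold higher number from compound 3 to compound 4 (0.00 log units; within the scatter). The earlier steps shown here changed only saturated ring and chain carbons, and none of them could be sized. The size of a number no higher from compound 2 to compound 4 (the limit leaves the size open) and of a number no higher from compound 1 to compound 4 (the limit leaves the size open) cannot be read either, because each of these steps starts from a limit and not a number: the limit of > 300000 nM in this assay, at which 2 of the 4 values shown sit.

On these data alone, the Z double bond appears only with the ring and chain configuration of compound 4, so its effect alongside the other configurations stays open. Also open, as far as these compounds go, is how this assay responds when an amine or a carboxylic acid replaces a hydroxyl group on the chain.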